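Aryl Piperazine Exchange and Alpha-1B Binding Affinity

The source may report more compounds than this note shows. Statements on the series, on what has been measured and on what is new or still open speak of the compounds shown alone.

Compound 2 `COC(=O)C1=C(C)NC(=O)N(C(=O)NCCCN2CCN(c3ccc(Cl)cc3)CC2)C1c1ccc(F)c(F)c1` gives, in an assay on liver for binding affinity to Alpha-1B adrenergic receptor (Homo sapiens), using microsomes (a higher number here means a weaker inhibitor, a lower number a stronger inhibitor), a value of 17 nM, the lowest of the two numbers measured, although its nearest neighbour, compound 1 `COC(=O)C1=C(C)NC(=O)N(C(=O)NCCCN2CCN(c3ccccc3OC)CC2)C1c1ccc(F)c(F)c1` with 18 nM in this assay, is separated from it only by a 1.1-fold lower number from compound 1 to compound 2 (0.02 log units; within the scatter), a gap within the scatter. Compound 3 `CCOc1ccccc1N1CCN(CCCNC(=O)N2C(=O)NC(C)=C(C(=O)OC)C2c2ccc(F)c(F)c2)CC1` has not yet been measured; it differs from compound 2 by 2-ethoxyphenyl in place of 4-chlorophenyl on an amine nitrogen in a ring. Among the measured compounds shown here, the single measured step that bears on this change is the exchange of 2-methoxyphenyl for 4-chlorophenyl, a 1.1-fold lower number from compound 1 to compound 2 (0.02 log units; within the scatter), which produced no movement beyond the scatter. Compound 3 is therefore expected to sit close to compound 2, with an estimated step of a 1.1-fold higher number from compound 2 to compound 3 (0.02 log units; within the scatter) that should not exceed the scatter. For compound 3 the expected value in this assay is 18 nM, with an estimated range from 7 nM to 45 nM.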

Compound 3, inhibition constant: 8.8 nM
Beside the measured number, compound 3's estimate is 2.0-fold (0.31 log units) above it, and the stated range covers the measured number.
By their numbers in this assay, from the lowest: compounds 3, 2 and 1 (each within the scatter of the next, the first and the last beyond it).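

In this assay, the exchange of 4-chlorophenyl for 2-ethoxyphenyl on the amine nitrogen in a ring gives a 1.9-fold lower number from compound 2 to compound 3 (0.29 log units; within the scatter) and so, like the earlier exchange at this position, stays inside the scatter. Among the compounds shown here, the smaller change, methyl in place of hydrogen on a saturated chain carbon bound to an oxygen on an aromatic ring, gives a 2.0-fold lower number from compound 1 to compound 3 (0.31 log units; beyond the scatter) and is the only step here to pass the scatter, though only modestly. Nothing measured on these compounds accounts for this step.

Going by these compounds, whether a propoxy group or a longer chain on the same oxygen would extend the step remains open. So does the reading for a hydroxyl group or an amine on that aromatic ring in this assay.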